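Compound 4 and a toxicity limit that stays unbroken

A few compounds are considered here, and "the series" means these few. Any claim that something is new, unique, unknown or untested is made for them only; others in the source may bear on it.

In an ADME assay on MDBK cells (Bos taurus) for cytotoxicity (on this read-out higher numbers stand for lower toxicity in this test and lower numbers for higher toxicity in this test), compound 3 (`c1ccc(-c2nc3ccn(CC4CCCCC4)cc-3n2)cc1`) gives only a limit, > 100000 nM. Compound 1 (`Clc1ccc(Cn2ccc3nc(-c4ccccc4)nc-3c2)cc1`) also gives a limit, > 100000 nM. Compound 2 (`N#Cc1ccccc1Cn1ccc2nc(-c3ccccc3)nc-2c1`) likewise gives a limit, > 100000 nM. The whole record for this assay is thus (the limit of > 100000 nM in this assay, at which 3 of the 3 values shown sit).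

Compound 4 (`Clc1ccc(Cn2ccc3nc(-c4ccccc4)nc-3c2)s1`) has not yet been measured. It carries 5-chlorothiophen-2-yl in place of cyclohexyl on a saturated chain carbon bound to an aromatic nitrogen.

Three measured steps change this same place: a step that the two limits leave unreadable from compound 1 to compound 3, a step that the two limits leave unreadable from compound 2 to compound 3 and a step that the two limits leave unreadable from compound 1 to compound 2. None of them has a readable size, so they offer no direction, and no step beyond the usual scatter is expected. The estimated change is a number no higher from compound 3 to compound 4 (the limit leaves the size open). This remains a weak expectation, as the new group has not been tested in this assay. For compound 4 the expected value is 100000 nM, with an estimated range from 40000 nM to 200000 nM.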

Compound 4, half-maximal cytotoxic concentration: > 100000 nM
Compound 4 ended at the assay's limit (the forecaster's own chance of this, stated with the estimate: 75%); the middle value lies on the limit itself.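

Compound 4, like compound 1, compound 2 and compound 3, gives only a limit in this assay and so none of its steps to them can be read: the limit of > 100000 nM in this assay, at which 4 of the 4 values shown sit. The compounds shown leave open how far toxicity in this test differs among these groups, since none has a measured half-maximal cytotoxic concentration.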